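Nitrophenyl Variation in a Coumarin Hydrazone Cytotoxicity Series

The compounds below may be only part of what the source reports. "The series", "measured", "known", "first", "only" and "open" are said of these compounds alone.

Measured compounds:
compound 1 `COc1cc(/C=C(\C#N)C(=O)N/N=C(\C)c2c(O)c3ccc(O)cc3oc2=O)ccc1O` gives 55400 nM
compound 2 `COc1ccc(/C=C(\C#N)C(=O)N/N=C(\C)c2c(O)c3ccc(O)cc3oc2=O)cc1OC` gives 45300 nM
compound 3 `C/C(=N\NC(=O)/C(C#N)=C/c1ccc([N+](=O)[O-])cc1)c1c(O)c2ccc(O)cc2oc1=O` gives 43200 nM

All three numbers were obtained in a functional assay on NRK-49F cells (Rattus norvegicus) for cytotoxicity, read by MTT assay, with a stated time of 24 h; a higher number here means a weaker inhibitor, a lower number a stronger inhibitor. Compound 2 sits among values that cannot be told apart: the step of a 1.2-fold lower number from compound 1 to compound 2 (0.09 log units; within the scatter) and the step of a 1.0-fold lower number from compound 2 to compound 3 (0.02 log units; within the scatter) both fall inside the usual scatter, so none of the three compounds can be called stronger or weaker than another on this evidence.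

Compound 4 `C/C(=N\NC(=O)/C(C#N)=C/c1ccccc1[N+](=O)[O-])c1c(O)c2ccc(O)cc2oc1=O` has not been measured in this assay. It differs from compound 2 in one place: 2-nitrophenyl in place of 3,4-dimethoxyphenyl on a double-bonded chain carbon bound to a double-bonded chain carbon. The closest guide is the step of a 1.0-fold lower number from compound 2 to compound 3 (0.02 log units; within the scatter), where compound 3 carries a nitrophenyl group in that same place and the number barely moved. The step of a 1.3-fold lower number from compound 1 to compound 3 (0.11 log units; within the scatter), again ending at a nitrophenyl compound, was also inside the scatter. For the measured compounds named here, no measured pair reports how the two nitrophenyl variants compare with each other, so that part of the change is untested.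

Given these steps, compound 4 is expected to show no change beyond the scatter, an expected step of a 1.0-fold lower number from compound 2 to compound 4 (0.00 log units; within the scatter). The estimate for compound 4 in this assay is 45000 nM, with a likely range from 22000 nM to 95000 nM.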

Compound 4, half-maximal inhibitory concentration: 68600 nM
Compound 4: the middle estimate sits 1.5-fold (0.18 log units) below what was measured; the range from low to high includes it.
By their numbers in this assay, from the lowest: compounds 3, 2, 1 and 4 (each within the scatter of the next).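

In this assay, for the compounds shown here, putting 2-nitrophenyl in place of 4-nitrophenyl gives a 1.6-fold higher number from compound 3 to compound 4 (0.20 log units; within the scatter), the first direct comparison of these two nitrophenyl variants on this double-bonded chain carbon, and moving the nitro group around the ring leaves a difference that cannot be told from assay noise. The 2-nitrophenyl group also cannot be separated from either ring that carries oxygen groups: against 3,4-dimethoxyphenyl the step is a 1.5-fold higher number from compound 2 to compound 4 (0.18 log units; within the scatter), and against 4-hydroxy-3-methoxyphenyl it is a 1.2-fold higher number from compound 1 to compound 4 (0.09 log units; within the scatter), so all four substituted phenyl groups shown here at this place give numbers that cannot be told apart, and no other data bear on why the numbers lie where they do.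

On these data alone, all four groups are substituted phenyl rings, so it remains open whether an amine, a carboxylic acid or a longer chain at this place would move the number beyond the scatter. As far as these compounds go, with only this one cell line and read-out, it also remains open whether the same lack of separation would hold in any other test.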